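Sulfonyl substituent swap in the hepatocyte clearance series

The source may report more compounds than this note shows. Statements on the series, on what has been measured and on what is new or still open speak of the compounds shown alone.

Compound 1 `CNC(=O)c1cc(S(=O)(=O)N2CCS[C@H]2C(=O)O[C@@H](Cc2c(Cl)c[n+]([O-])cc2Cl)c2ccc(OC(F)F)c(OCC3CC3)c2)cn1C` gives 47.6 uL/min in an ADME assay on cells (Hepatocyte, Homo sapiens) for metabolic stability, read by LC-MS, with a stated time of 90 min, tested at 1 uM; a higher number here means faster removal of the compound, a lower number slower removal.
Compound 2 `CN(C)C(=O)c1cccc(S(=O)(=O)N2CSC[C@H]2C(=O)O[C@@H](Cc2c(Cl)c[n+]([O-])cc2Cl)c2ccc(OC(F)F)c(OCC3CC3)c2)c1` gives 25.9 uL/min in this assay.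
Compound 3 `COc1ccc(S(=O)(=O)N2CCCC[C@H]2C(=O)O[C@@H](Cc2c(Cl)c[n+]([O-])cc2Cl)c2ccc(OC(F)F)c(OCC3CC3)c2)cc1C(=O)N(C)C` gives 33.2 uL/min in this assay.

Compound 1 holds the highest of the three numbers, but its gap to compound 3 and its gap to compound 2 both fall within the scatter, so no ranking among the three is supported. Compound 4 `Cn1cnc(S(=O)(=O)N2CCS[C@H]2C(=O)O[C@@H](Cc2c(Cl)c[n+]([O-])cc2Cl)c2ccc(OC(F)F)c(OCC3CC3)c2)c1` differs from compound 1 by a group of 6 heavy atoms (4 carbon, 2 nitrogen; one five-membered aromatic ring with 2 hetero atoms) in place of a group of 10 heavy atoms (7 carbon, 2 nitrogen, 1 oxygen; one five-membered aromatic ring with 1 hetero atom), on a sulfonyl sulfur. Among the compounds with values here, no pair of measured compounds shares this change, so nothing calibrates it. The expected step of a 1.3-fold lower number from compound 1 to compound 4 (0.12 log units; within the scatter) is small, leaning toward a lower number, and not clearly beyond the scatter. For compound 4 the estimate in this assay is 36 uL/min, with a range from 18 uL/min to 72 uL/min.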

Compound 4, intrinsic clearance in a liver preparation (reported as CLH), per the amount of preparation that the assay uses: 66.9 uL/min
For compound 4 the middle estimate is 1.9-fold (0.27 log units) below the measured one, within the range that was stated.
By their numbers in this assay, from the lowest: compounds 2, 3, 1 and 4 (each within the scatter of the next, the first and the last beyond it).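

Within the data shown here, on the sulfonyl sulfur, 1-methyl-1H-imidazol-4-yl in place of the larger group of compound 1 gives a 1.4-fold higher number from compound 1 to compound 4 (0.15 log units; within the scatter) in this assay, the first single-place step. At this position, the group carrying a hydrogen-bond donor can therefore give way to a smaller ring with 0 hydrogen-bond donors without a shift clear of the scatter. No measurement shown offers an explanation for this step.

One pair cannot define the tolerance of this position. Open, from the compounds shown here alone, is whether a methyl group or a ring bearing a carboxylic acid on the sulfonyl sulfur would move clearance beyond the scatter from compound 1.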